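Two measured analogues and one methoxyphenyl variant

The source may hold more compounds than are shown below. What is called first, only, known or untested is meant among the compounds shown, and "the series" means these compounds.

Of the compounds shown here, two have been measured so far. Compound 1 `CC(C)(C)c1ccc(OCCCON2C(N)=NC(N)=NC23CCSCC3)cc1` and compound 2 `NC1=NC2(CCSCC2)N(OCCCOc2ccccc2Cl)C(N)=N1` share the same core and differ only in the aromatic group at the end of the chain. In an assay on isolated protein for inhibition of Dihydrofolate reductase (Homo sapiens), read by spectrophotometry, using NADPH, with stated times of 5 s and 6 min, tested at 5 uM (a higher number here means a stronger effect of the compound at the concentration tested, a lower number a weaker effect), compound 1 gives 85.3%. In this assay compound 2 gives 86.3%. Compound 2 stands at the higher of the two numbers shown, though its gap to compound 1 lies within the scatter, so the two compounds cannot be ordered on these data.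

Compound 3 `COc1ccc(OCCCON2C(N)=NC(N)=NC23CCSCC3)cc1` has not yet been measured. It differs from compound 2 as follows: 4-methoxyphenyl in place of 2-chlorophenyl on an oxygen on a saturated carbon. Going by the values given here, no step between measured compounds exists against which this change can be weighed. Since both measured aromatic groups give high inhibition, the step of a number 2.3 percentage points lower from compound 2 to compound 3 (within the scatter) is expected to be small, none beyond the scatter. Compound 3 is therefore expected to give about 84%, within 72% to 92%.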

Compound 3, a percentage reported as inhibition, at one concentration (the size of the read-out at that concentration, not a potency): 81.3%
The estimate for compound 3 lay 2.7 percentage points above the measured number; the measured number falls inside the stated range.
By their numbers in this assay, from the lowest: compounds 3, 1 and 2 (each within the scatter of the next).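

In this assay, the aromatic group on an oxygen on a saturated carbon now tolerates a further change: 4-methoxyphenyl in place of 2-chlorophenyl gives a number 5 percentage points lower from compound 2 to compound 3 (within the scatter). On the same position, methoxy in place of tert-butyl on an aromatic carbon gives a number 4 percentage points lower from compound 1 to compound 3 (within the scatter), so neither step separates the compounds, even though the entering 4-methoxyphenyl counts a hydrogen-bond acceptor that 2-chlorophenyl lacks. Nothing available explains these numbers.

All three compounds carry a substituted phenyl group and are read at one concentration, so any differences in potency among them remain unresolved. From the compounds shown here alone, whether an amine, a carboxylic acid or a longer chain at this position would move the number beyond the scatter remains open.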